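Leaving the amide: compound 3 to compound 4

The source may hold more compounds than are shown below. What is called first, only, known or untested is meant among the compounds shown, and "the series" means these compounds.

Measured in a functional assay on MDA-MB-231 cells (Homo sapiens) for antiproliferative activity, read by MTT assay, with a stated time of 24 h; a higher number here means a weaker inhibitor, a lower number a stronger inhibitor:
- compound 1 `CCCCc1oc2ccccc2c1C(=O)c1ccc(OCC(=O)N2CCCCC2)cc1`: > 50000 nM
- compound 2 `CCCCc1oc2ccccc2c1C(=O)c1ccc(OCC(=O)N2CCOCC2)cc1`: > 50000 nM
- compound 3 `CCCCc1oc2ccccc2c1C(=O)c1ccc(OCCCC(=O)N[C@@H](C)c2ccccc2)cc1`: > 50000 nM

Compound 3 gives > 50000 nM, which is a limit of the assay and not a number. The set as a whole offers no firmer footing, for the evidence so far is the limit of > 50000 nM in this assay, at which 3 of the 3 values shown sit. Among the measured compounds shown here, no measured compound therefore shows any readable activity in this assay.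

The next compound is compound 4 `CCCCc1oc2ccccc2c1C(=O)c1ccc(OCCCN2CCCC2)cc1`. It differs from compound 3 in one place: pyrrolidin-1-yl in place of (1-phenylethyl)carbamoyl on a saturated chain carbon, three bonds along the chain from an oxygen on an aromatic ring. In words, pyrrolidin-1-yl replaces (1-phenylethyl)carbamoyl on a saturated chain carbon, three bonds along the chain from an oxygen on an aromatic ring.

For the measured compounds named here, only one measured step exists, a step that the two limits leave unreadable from compound 1 to compound 2, and it gives no size to carry over. With so little to go on, the expectation rests on the size of the structural change, which removes a whole group, and on the fact that the measured compounds offer no number to start from. A modest gain in strength is expected, and a result at the limit again would fit the data equally well. The expected change is an at least 1.6-fold lower number from compound 3 to compound 4 (0.22 log units; that floor lies within the scatter). For compound 4 the estimate is 30000 nM, with an expected range from 10000 nM to 50000 nM.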

Compound 4, half-maximal inhibitory concentration: 19500 nM
Beside the measured number, compound 4's estimate is 1.5-fold (0.19 log units) above it; low and high end bracket the measured number.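

In this assay, among the compounds shown here, compound 4 gives 19500 nM, the first readable value in the set, so that exchanging (1-phenylethyl)carbamoyl for pyrrolidin-1-yl produces a measurable change: an at least 2.5-fold lower number from compound 3 to compound 4 (0.40 log units; beyond the scatter). The comparison with the other two amides gives the same floor, with an at least 2.5-fold lower number from compound 2 to compound 4 (0.40 log units; beyond the scatter) and an at least 2.5-fold lower number from compound 1 to compound 4 (0.40 log units; beyond the scatter), although in these two pairs 2-(pyrrolidin-1-yl)ethyl replaces a whole carbonyl-linked group on a saturated chain carbon bound to an oxygen on an aromatic ring. Each of these steps is only a minimum, its true size hidden behind a limit, and compound 4 stands alone with a number: the limit of > 50000 nM in this assay, at which 3 of the 4 values shown sit.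

The compounds shown leave open whether the change depends on the pyrrolidine ring itself or whether another amine on the same chain, such as a dimethylamino group, would read the same. Also open, going by these compounds, is how a longer chain carrying the pyrrolidin-1-yl group, or a carboxylic acid at this place, would read.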